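The compounds below may be only part of what the source reports. "The series", "measured", "known", "first", "only" and "open" are said of these compounds alone.

In a functional assay on QGY-7703 cells (Homo sapiens) for cytotoxicity, read by MTT assay, with a stated time of 24 h (a lower number here means a stronger inhibitor, a higher number a weaker inhibitor), compound 1 `COc1cc(/C=C2\CN(C)C/C(=C\c3cccnc3)C2=O)cc(OC)c1OC` gives 4300 nM and compound 2 `COc1cc(/C=C2\CN(C)C/C(=C\c3ccncc3)C2=O)cc(OC)c1` gives 8400 nM. These two values lie within the usual scatter of repeated measurements, so compound 2 cannot be told apart from compound 1 on these numbers.

Compound 3 `COc1cc(/C=C2\CN(C)C/C(=C\c3ccncc3)C2=O)cc(OC)c1OC` differs from compound 2 in a single place, (methoxy in place of hydrogen on an aromatic carbon). It has methoxy in place of hydrogen on an aromatic carbon, ortho to two methoxy groups and para to a large group.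

Comparing two compounds that differ in one place is the cleanest way to read the effect of a change, but no such pair has been measured here. The data therefore hold no direct measure of what this added methoxy does in this assay. With so little to go on, the safest expectation is no change beyond the scatter, and the value of compound 3 is expected to stay in the range already seen. The estimated step is a 1.4-fold lower number from compound 2 to compound 3 (0.15 log units; within the scatter), a small one. For compound 3 the expected value is 6000 nM, with an estimated range from 2500 nM to 14000 nM.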

Compound 3, half-maximal inhibitory concentration: 5900 nM
Compound 3: middle estimate off by 1.0-fold (0.01 log units), on the high side; low and high end bracket the measured number.
By their numbers in this assay, from the lowest: compounds 1, 3 and 2 (each within the scatter of the next).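

In this assay, within the data shown here, the first direct pair at this position puts a methoxy in place of hydrogen on an aromatic carbon, ortho to two methoxy groups and para to a large group, and the result is a small step (a 1.4-fold lower number from compound 2 to compound 3 (0.15 log units; within the scatter)), so this added group brings no change that can be told apart from the scatter. A second direct pair puts pyridin-4-yl in place of pyridin-3-yl on a double-bonded chain carbon bound to a double-bonded ring carbon, and this step (a 1.4-fold higher number from compound 1 to compound 3 (0.14 log units; within the scatter)) also cannot be told apart from the scatter, so neither single change has a readable effect among these three compounds. No additional measurement is available to help explain these two results.

From the compounds shown here alone, it remains open whether a different group on the same aromatic carbon, such as an amine or a carboxylic acid, would shift the number beyond the scatter. Going by these compounds, it is also open whether a thiophene ring in place of the pyridine, or a longer chain in place of the methyl on the shared core, would do so.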